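One Carbon More on the Chain of Compound 2

This account rests on a few compounds, and the source may have more. Where it says the series, first, only, none or still open, it means among the compounds named here.

compound 1, `O=C(CCCc1ccccc1)N[C@H]1CCOC1=O`: > 100000 nM in a functional assay on NCI-H630 cells (Homo sapiens) for cytotoxicity, read by sulforhodamine B assay, with a stated time of 5 days; on this read-out higher numbers stand for weaker inhibition and lower numbers for stronger inhibition
compound 2, `O=C(CCCCCc1ccccc1)N[C@H]1CCOC1=O`: > 100000 nM in this assay
compound 3, `O=C(CCCc1ccccc1)CC(=O)N[C@H]1CCOC1=O`: > 100000 nM in this assay

Each of these three values is a limit of the assay, not a number. Compound 2 therefore stands nowhere in particular among them: it sits at the limit of > 100000 nM in this assay, at which 3 of the 3 values shown sit, and no difference between the measured compounds can be read from the data. Compound 4, `O=C(CCCCCCc1ccccc1)N[C@H]1CCOC1=O`, differs from compound 2 by benzyl in place of phenyl on a saturated chain carbon, five bonds along the chain from a carbonyl carbon. With every measured compound at the limit, the step expected from compound 2 to compound 4 in this assay is none beyond the scatter, a step that the limit leaves unreadable from compound 2 to compound 4. Compound 4 is thus expected to give roughly 150000 nM, within 50000 nM to 500000 nM, most probably again reported only as a limit.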

Compound 4, half-maximal inhibitory concentration: > 100000 nM
Compound 4: a limit, no number (the forecaster's own chance of this, stated with the estimate: 85%); the middle value lies beyond the limit too.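

Compound 4 gives no readable step from compound 2, since both values are limits and not numbers: the limit of > 100000 nM in this assay, at which 4 of the 4 values shown sit.

The compounds shown leave open whether chain length changes the result in this assay at all.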